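Adding a Methyl Group: Expected Effect on Cytotoxicity

This account rests on a few compounds, and the source may have more. Where it says the series, first, only, none or still open, it means among the compounds named here.

Of the compounds shown here, three built on a shared core have been tested in an ADME assay on L929 cells (Mus musculus) for cytotoxicity, read by resazurin assay, with a stated time of 72 h; on this read-out higher numbers stand for weaker inhibition and lower numbers for stronger inhibition. Compound 1 `OB1OCc2ccc(-n3cc(Sc4ccc(Cl)c(Cl)c4)c4ccccc43)cc21` reached only the limit of the assay, > 10 ug/mL. Compound 2 `COc1ccc(CNC(=O)c2cccn2-c2ccc3c(c2)B(O)OC3)cc1` likewise stops at a limit, > 10 ug/mL. Compound 3 `O=C(c1ccccc1)c1ccn(-c2ccc3c(c2)B(O)OC3)c1` also gives a limit rather than a number, > 10 ug/mL. Within the data shown here, compound 3 thus stands where all three values shown stand, at the limit of > 10 ug/mL in this assay, at which 3 of the 3 values shown sit; no value separates it from the other two, and no step between measured compounds exists to compare.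

Compound 4 `Cc1ccc(C(=O)c2ccn(-c3ccc4c(c3)B(O)OC4)c2)cc1` differs from compound 3 in one place: methyl in place of hydrogen on an aromatic carbon, a methyl in place of hydrogen on an aromatic carbon. Among the measured compounds shown here, every result so far is a limit, and no measured step guides the size of this change. The expectation is that the step from compound 3 to compound 4 in this assay amounts to a step that the limit leaves unreadable from compound 3 to compound 4, nothing beyond the usual scatter. Compound 4 is therefore estimated to give 20 ug/mL in this assay, between 8 ug/mL and 60 ug/mL, and most probably once more reported only as a limit.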

Compound 4, half-maximal inhibitory concentration: > 10 ug/mL
Compound 4 ended at the assay's limit; the forecaster's own chance of this, stated with the estimate: 85%; the middle value does not contradict the limit.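

Compound 3 and compound 4 both stop at a limit in this assay, so the change from phenyl to 4-methylphenyl gives no readable step: the limit of > 10 ug/mL in this assay, at which 4 of the 4 values shown sit.

The compounds shown leave open how strongly any of them inhibits these cells, and whether that methyl changes it at all.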